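The compounds below may be only part of what the source reports. "The series", "measured", "known", "first", "only" and "open" are said of these compounds alone.

Measured so far in an ADME assay on 697 cells (Homo sapiens) for cytotoxicity, with a stated time of 48 h; a higher number here means a weaker inhibitor, a lower number a stronger inhibitor:

compound 1 `Cn1c(Sc2c(F)cc(C(=O)NO)cc2F)nnc1-c1cccnn1` — > 1000 nM
compound 2 `O=C(NO)c1ccc(Cn2nnc(-c3ncccn3)n2)cc1` — > 1000 nM
compound 3 `O=C(NO)c1cc(F)c(Cn2nnc(-c3ccccn3)n2)c(F)c1` — > 1000 nM

Each of these three readings is a limit of the assay, not a measured number. Compound 3 therefore has no exact position; its reading of > 1000 nM only says that it sits at the limit. Among the compounds with values here, the same holds for the whole set, as the limit of > 1000 nM in this assay, at which 3 of the 3 values shown sit, shows, so there is no ordering among the three and no compound can be called stronger or weaker than another. Within the data shown here, no two of the measured compounds differ in just one place, so no measured step exists to lean on.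

Compound 4 `O=C(NO)c1cc(F)c(Cn2nnc(-c3ccco3)n2)c(F)c1` is the next compound, and it differs from compound 3 by furan-2-yl in place of pyridin-2-yl on an aromatic carbon. With every shown value at the limit, the step from compound 3 to compound 4 is expected to be none beyond the scatter, as far as this assay can tell: a step that the limit leaves unreadable from compound 3 to compound 4. Compound 4 is estimated at 3000 nM, within 1000 nM to 10000 nM, and is most likely to be reported once more only as a limit.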

Compound 4, half-maximal inhibitory concentration: > 1000 nM
Compound 4: no number, only a limit; the forecaster's own chance of this, stated with the estimate: 85%; the middle value is on the limit's open side.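

No step can be read from compound 3 to compound 4, since both readings are limits rather than numbers, as is every other reading here: the limit of > 1000 nM in this assay, at which 4 of the 4 values shown sit.

As far as these compounds go, what stays open is where any of the four compounds truly sits in this assay, and whether furan-2-yl in place of pyridin-2-yl changes anything there.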